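Same Atoms, Joined Differently: One Number Among Limits

The source may report more compounds than this note shows. Statements on the series, on what has been measured and on what is new or still open speak of the compounds shown alone.

Measured so far:
compound 1, `O=C(COc1c(-c2ccccc2)oc2ccccc2c1=O)Nc1ccc(F)cc1`, > 10000 nM
compound 2, `COc1ccc(NC(=O)COc2c(-c3ccccc3)oc3ccccc3c2=O)cc1`, > 10000 nM
compound 3, `O=C(COc1ccc2oc(-c3ccccc3)cc(=O)c2c1)Nc1ccc(F)cc1`, 470 nM

All three were tested in a functional assay on MT2 cells (Homo sapiens) for antiproliferative activity, read by MTT assay, with a stated time of 72 h; a lower number here means a stronger inhibitor of growth, a higher number a weaker inhibitor of growth. For compound 1 the value is a limit of the assay, not a number. For compound 2 the value is likewise a limit. The step that the two limits leave unreadable from compound 1 to compound 2, which is methoxy in place of fluoro on an aromatic carbon, therefore cannot be sized, because both ends sit at the limit of > 10000 nM in this assay, at which 2 of the 3 values shown sit. Compound 3 has the same atoms as compound 1, joined differently; the difference between the two cores is not broken down here. In this assay, going by the values given here, compound 3 gives 470 nM, the only number among the three.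

Compound 4, `COc1ccc(NC(=O)COc2ccc3oc(-c4ccccc4)cc(=O)c3c2)cc1`, is not yet measured. It differs from compound 3 by methoxy in place of fluoro on an aromatic carbon, the same change as from compound 1 to compound 2, at a place described in the same words. Since the measured instance of this change is unreadable, the step of a 1.3-fold higher number from compound 3 to compound 4 (0.11 log units; within the scatter) is expected to be small. Compound 4 is estimated at 600 nM, likely between 200 nM and 2500 nM.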

Compound 4, concentration for 50% growth inhibition: 3010 nM
Beside the measured number, compound 4's estimate is 5.0-fold (0.70 log units) below it, and the stated range ends below it.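

On the core that gives real numbers, methoxy in place of fluoro produces a 6.4-fold higher number from compound 3 to compound 4 (0.81 log units; beyond the scatter) in this assay, a loss of growth inhibition. That is a single pair on a single core, so it shows what the change does there and gives no rule for how the same change behaves on any other core. On the core of compound 1 the change cannot be sized, because compound 1 and compound 2 each give only a limit of the assay, not a number: the limit of > 10000 nM in this assay, at which 2 of the 4 values shown sit.

The compounds shown leave open whether an amine or a carboxylic acid in place of fluoro would keep, improve or lose the growth inhibition seen with compound 3. They also leave open what a longer chain in place of methoxy would do, and whether any group on the core of compound 1 would give a readable number at all.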